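Swapping a Sulfonamide for a Tetrazole on a Shared Core

The compounds below may be only part of what the source reports. "The series", "measured", "known", "first", "only" and "open" are said of these compounds alone.

Compound 1, `CCCS(=O)(=O)Nc1ccc(F)c(C(=O)c2n[nH]c3ncc(-c4ccc(S(=O)(=O)NC(C)=O)cc4)cc23)c1F`: 0.5%
Compound 2, `CCCS(=O)(=O)Nc1ccc(F)c(C(=O)c2n[nH]c3ncc(-c4ccc(NS(C)(=O)=O)cc4)cc23)c1F`: 16%

Among the compounds with values here, in an assay for binding affinity to dual specificity mitogen-activated protein kinase kinase 4 (Homo sapiens), read by KINOMEscan, tested at 10 nM (on this read-out lower numbers stand for a stronger effect and higher numbers for a weaker effect at the one concentration tested), compound 2 gives 16%, the higher of the two numbers measured so far and therefore the weaker effect; compound 1 gives 0.5%. Within the data shown here, the two differ in one group on the shared core, and that single step, a number 15.5 percentage points higher from compound 1 to compound 2 (beyond the scatter), is the only step known here. Compound 3, `CCCS(=O)(=O)Nc1ccc(F)c(C(=O)c2n[nH]c3ncc(-c4ccc(-c5nnn[nH]5)cc4)cc23)c1F`, has not yet been measured. It differs from compound 2 in one place: 1H-tetrazol-5-yl in place of methanesulfonamido on an aromatic carbon. Among the measured compounds shown here, no measured step turns this group into a ring, so the step from compound 1 to compound 2 bears on it only by showing that exchanging the group at this place shifted the read-out by a modest amount. A modest shift is therefore expected, and the data give no direction for it. Compound 3 is expected to give 10%, within a range from 0.5% to 40%. The expected step is a number 6 percentage points lower from compound 2 to compound 3 (within the scatter).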

Compound 3, a percentage reported as activity, at one concentration (the size of the read-out at that concentration, not a potency): 1.1%
Beside the measured number, compound 3's estimate is 8.9 percentage points above it; the range from low to high includes it.
By their numbers in this assay, from the lowest: compounds 1 and 3 (each within the scatter of the next); then compound 2.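

In this assay, the 1H-tetrazol-5-yl group shows that a ring can stand at this place on the aromatic ring and still give a strong effect: a number 14.9 percentage points lower from compound 2 to compound 3 (beyond the scatter), a step of similar size to the earlier one but in the opposite direction. Set against the acetylsulfamoyl group, the same ring gives a number 0.6 percentage points higher from compound 1 to compound 3 (within the scatter), so these two quite different groups read alike here. Among these three compounds, methanesulfonamido is the group that stands apart, which shows that a strong effect at this place does not depend on having either a ring or an open group.

Going by these compounds, it remains open whether a carboxylic acid or an amine at this place would read like compound 1 and compound 3 or like compound 2. Nothing measured here explains the differences between these groups.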